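From 3-chlorophenyl to 4-methoxyphenyl on the shared core

The source may report more compounds than this note shows. Statements on the series, on what has been measured and on what is new or still open speak of the compounds shown alone.

Compound 1 `COC(=O)/C(=C/c1ccccc1)CN1C(=O)[C@@H](OC)[C@H]1c1ccc(Cl)cc1`: 15600 nM
Compound 2 `COC(=O)/C(=C/c1ccccc1)CN1C(=O)[C@@H](OC)[C@H]1c1ccc(F)cc1`: 21800 nM
Compound 3 `COC(=O)/C(=C/c1ccccc1)CN1C(=O)[C@@H](OC)[C@H]1c1cccc(Cl)c1`: no result reported

These compounds were examined in a functional assay on MDA-MB-231 cells (Homo sapiens) for antiproliferative activity, read by MTT assay, with a stated time of 48 h; on this read-out higher numbers stand for weaker inhibition and lower numbers for stronger inhibition. Compound 3 has no number in this assay, so it gives no fixed starting point for the next step. That step leads to compound 4 `COC(=O)/C(=C/c1ccccc1)CN1C(=O)[C@@H](OC)[C@H]1c1ccc(OC)cc1`, and the change is 4-methoxyphenyl in place of 3-chlorophenyl on a saturated ring carbon, next to the ring nitrogen. Among the compounds with values here, no measured step covers this exchange directly. The closest evidence is a 1.4-fold higher number from compound 1 to compound 2 (0.15 log units; within the scatter), a change of fluoro in place of chloro on an aromatic carbon that stays within the scatter. That step involves a different substituent, so it offers only weak guidance. No direction can be assigned from compound 3, and compound 4 is expected to fall in the same general region as compound 1 and compound 2, with a wide margin. For compound 4 the expected value is estimated at 20000 nM, within an estimated range of 8000 nM to 50000 nM.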

Compound 4, half-maximal inhibitory concentration: 14000 nM
Estimate against measurement, compound 4: 1.4-fold (0.15 log units) above; measured number inside the range.
By their numbers in this assay, from the lowest: compounds 4, 1 and 2 (each within the scatter of the next).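

Compound 4 brings the first oxygen-bearing substituent to the aryl group on the saturated ring carbon of the four-membered ring, and in this assay methoxy in place of fluoro gives a 1.6-fold lower number from compound 2 to compound 4 (0.19 log units; within the scatter), while methoxy in place of chloro gives a 1.1-fold lower number from compound 1 to compound 4 (0.05 log units; within the scatter). The earlier compounds shown here compared only two halogens, whereas these steps show that a substituent with a hydrogen-bond acceptor also leaves the number within the scatter of both halogen compounds, so the three compounds cannot be ordered. The step from compound 3 to compound 4 cannot be read, and nothing available explains the result.

The compounds shown leave open whether an amine or a carboxylic acid on this aromatic ring would stay in the same region. They also leave open how the 3-chlorophenyl group of compound 3 compares with the other aryl groups.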